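Inverting the Stereocentre of Compound 2

The compounds below may be only part of what the source reports. "The series", "measured", "known", "first", "only" and "open" are said of these compounds alone.

In a functional assay on HCT-15 cells (Homo sapiens) for antiproliferative activity, with a stated time of 48 h (a higher number here means a weaker inhibitor, a lower number a stronger inhibitor), compound 1 `Cc1cc(=O)c2c(O)cc(OCC3CO3)cc2o1` gives 18300 nM and compound 2 `Cc1cc(=O)c2c(O)cc(OC[C@H]3CO3)cc2o1` gives 27200 nM, two values within the scatter of each other. Compound 3 `Cc1cc(=O)c2c(OC[C@H]3CO3)cc(OC[C@H]3CO3)cc2o1` gives 229000 nM, which leaves compound 2 clearly on the stronger side, with an 8.4-fold higher number from compound 2 to compound 3 (0.93 log units; beyond the scatter). Compound 4 `Cc1cc(=O)c2c(O)cc(OC[C@@H]3CO3)cc2o1` changes only the stereocentre at a saturated ring carbon, drawn R in compound 2 and S in compound 4: the two compounds have the same atoms and bonds and differ only in configuration as drawn: 1 of 1 stereo elements differ; a stereocentre at a saturated ring carbon is drawn R in compound 2 and S in compound 4. Among the compounds with values here, the one measured step touching this stereocentre is a 1.5-fold higher number from compound 1 to compound 2 (0.17 log units; within the scatter), and it reflects (the fact that one of compounds 1 and 2 is drawn with a defined configuration and the other without, at the place where they differ). With that step so small, no change beyond the scatter is expected. The expected step is a 1.6-fold lower number from compound 2 to compound 4 (0.20 log units; within the scatter). In this assay, compound 4 is estimated at 17000 nM, within an expected range of 8000 nM to 36000 nM.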

Compound 4, half-maximal inhibitory concentration: 17500 nM
Beside the measured number, compound 4's estimate is 1.0-fold (0.01 log units) below it; the measured number falls inside the stated range.
By their numbers in this assay, from the lowest: compounds 4, 1 and 2 (each within the scatter of the next); then compound 3.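

Within the data shown here, compound 4 gives the first direct comparison of the two drawn configurations at this saturated ring carbon, and in this assay the step is a 1.6-fold lower number from compound 2 to compound 4 (0.19 log units; within the scatter). The other new step is a 1.0-fold lower number from compound 1 to compound 4 (0.02 log units; within the scatter), so the form drawn without a configuration also stays within the scatter of compound 4. This assay therefore shows no preference between R and S at this position, for a pair separated by one thing alone: the fact that compounds 2 and 4 differ only in the configuration as drawn. The compounds shown leave open whether configuration matters when the (oxiran-2-yl)methyl group stands on both oxygens, as in compound 3. They also leave open how an amine or a longer chain would compare in place of that group.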